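Swapping Fluoro for Methyl on the Pyridine Arm

The source may report more compounds than this note shows. Statements on the series, on what has been measured and on what is new or still open speak of the compounds shown alone.

Measured so far:
- compound 1, `O=C(O)Cc1sc(C(c2ccc(F)cc2)c2ccc(F)cc2)nc1-c1cccc(F)c1`: 1.4 nM
- compound 2, `O=C(O)Cc1sc(C(c2ccc(F)cc2)c2ccc(F)cc2)nc1-c1cn[nH]c1`: 16 nM
- compound 3, `O=C(O)Cc1sc(C(c2ccc(F)cc2)c2ccc(F)cc2)nc1-c1ccnc(F)c1`: 0.48 nM

All three share one core and differ only in the aromatic group attached to it. In an in vitro assay on HEK385-7 cells for displacement of a labelled ligand from prostaglandin D2 receptor 2 (Homo sapiens) (on this read-out lower numbers stand for stronger inhibition and higher numbers for weaker inhibition), compound 3 gives the lowest number of the three, beyond the scatter from both others: a 2.9-fold lower number from compound 1 to compound 3 (0.46 log units; beyond the scatter) and a 33-fold lower number from compound 2 to compound 3 (1.52 log units; beyond the scatter). Compound 4, `Cc1cc(-c2nc(C(c3ccc(F)cc3)c3ccc(F)cc3)sc2CC(=O)O)ccn1`, keeps the pyridine arm of compound 3 and makes a small change there: methyl in place of fluoro on an aromatic carbon.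

Going by the values given here, none of the measured steps concerns this particular exchange. The steps seen so far, an 11-fold higher number from compound 1 to compound 2 (1.06 log units; beyond the scatter) and a 2.9-fold lower number from compound 1 to compound 3 (0.46 log units; beyond the scatter), replace the whole aromatic arm, and the large one involves a five-membered ring in place of a six-membered one. The present change keeps the ring and its nitrogen and alters only one small substituent. A step far smaller than those is therefore expected in this assay, with the direction uncertain and perhaps no change beyond the scatter; a slight weakening is taken as the middle estimate, a 1.9-fold higher number from compound 3 to compound 4 (0.27 log units; within the scatter). Compound 4 is thus estimated at 0.9 nM, within 0.3 nM to 3 nM.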

Compound 4, half-maximal inhibitory concentration: 3.1 nM
The estimate for compound 4 lay 3.4-fold (0.54 log units) below the measured number, outside the stated range (above it).
By their numbers in this assay, from the lowest: compound 3; then compound 1; then compound 4; then compound 2.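

In this assay, the exchange of fluoro for methyl next to the ring nitrogen is not a silent one: a 6.5-fold higher number from compound 3 to compound 4 (0.81 log units; beyond the scatter) even though the ring and its nitrogen stay in place and one heavy atom replaces one heavy atom. This single substituent therefore moves the number further than the whole-arm exchange that gave a 2.9-fold lower number from compound 1 to compound 3 (0.46 log units; beyond the scatter) did. The pyridine ring alone also does not decide the ranking, since the 2-methylpyridin-4-yl arm still improves on the pyrazole with a 5.2-fold lower number from compound 2 to compound 4 (0.71 log units; beyond the scatter) yet loses to the 3-fluorophenyl arm with a 2.2-fold higher number from compound 1 to compound 4 (0.35 log units; beyond the scatter) and so reverses the edge that the fluoropyridine held.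

Nothing shown here accounts for the size of this step. From the compounds shown here alone, whether chloro, methoxy or an amine at this place would land nearer compound 3 or compound 4 remains open.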